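A few compounds are considered here, and "the series" means these few. Any claim that something is new, unique, unknown or untested is made for them only; others in the source may bear on it.

Working notes on the series. Two members have numbers in a functional assay on OVCAR-5 cells (Homo sapiens) for inhibition, read by CCK-8 assay, with a stated time of 72 h, tested at 10 uM; a lower number here means less inhibition of growth, a higher number more inhibition of growth at the concentration tested. Compound 1 `CN(C)C(=O)c1cc2cnc(Nc3ccc(NC(=O)C4(C(=O)Nc5ccc(Cl)c(C(F)(F)F)c5)CC4)cc3)nc2n1C1CCCC1` gives 48%, while compound 2 `CN(C)C(=O)c1cc2cnc(Nc3ccc(NC(=O)C4(C(=O)Nc5ccc(O)cc5)CC4)cc3)nc2n1C1CCCC1` gives 90.9%, the higher of the two numbers. For the measured compounds named here, the single measured step, a number 42.9 percentage points higher from compound 1 to compound 2 (beyond the scatter), is the only one that bears on the next change. Compound 3 `CN(C)C(=O)c1cc2cnc(Nc3ccc(NC(=O)C4(C(=O)Nc5cccc(F)c5)CC4)cc3)nc2n1C1CCCC1` differs from compound 2 by 3-fluorophenyl in place of 4-hydroxyphenyl on an amide-type nitrogen. A downward step is expected on this assay, because compound 1 with its 4-chloro-3-(trifluoromethyl)phenyl gives 48%, and the fluorophenyl change is expected to run part of the way back: a number 28.9 percentage points lower from compound 2 to compound 3 (beyond the scatter). Compound 3 is estimated at 62%, within 38% to 86%.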

Compound 3, percent growth inhibition at one concentration: 85.6%
For compound 3 the middle estimate is 23.6 percentage points below the measured one; the range from low to high includes it.
By their numbers in this assay, from the lowest: compound 1; then compounds 3 and 2 (each within the scatter of the next).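

In this assay, this amide-type nitrogen accepts 3-fluorophenyl in place of 4-hydroxyphenyl with a number 5.3 percentage points lower from compound 2 to compound 3 (within the scatter), so within these compounds the hydrogen-bond donor and acceptor counted on 4-hydroxyphenyl are not needed to keep the number high. The change from 4-chloro-3-(trifluoromethyl)phenyl gives a number 37.6 percentage points higher from compound 1 to compound 3 (beyond the scatter), so a halogen on the phenyl does not by itself bring the low number of compound 1. No measurement on hand accounts for either step. Still open, going by these compounds, is whether the chlorine or the trifluoromethyl carries the low number of compound 1. On these data alone, how an aminophenyl or a carboxyphenyl would read on this nitrogen is also open.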